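Ester side-chain variation: cytotoxicity notes on the series

The compounds below may be only part of what the source reports. "The series", "measured", "known", "first", "only" and "open" are said of these compounds alone.

Measured so far:
compound 1 `CCCCC(=O)OCCc1c(-c2ccccc2Cl)c2cc(Cl)ccc2[nH]c1=O` — 200000 nM
compound 2 `COCC(=O)OCCc1c(-c2ccccc2Cl)c2cc(Cl)ccc2[nH]c1=O` — 74000 nM
compound 3 `O=C(OCCc1c(-c2ccccc2Cl)c2cc(Cl)ccc2[nH]c1=O)C1CCCCC1` — 38000 nM

In an ADME assay on HepG2 2.2.15 cells (Homo sapiens) for cytotoxicity (a higher number here means that more compound is tolerated, a lower number that less compound is tolerated), compound 3 carries the lowest of the three numbers, though the step of a 1.9-fold lower number from compound 2 to compound 3 (0.29 log units; within the scatter) lies within the scatter, while a 5.3-fold lower number from compound 1 to compound 3 (0.72 log units; beyond the scatter) lies beyond it. Compound 4 `O=C(CCOc1ccccc1)OCCc1c(-c2ccccc2Cl)c2cc(Cl)ccc2[nH]c1=O` differs from compound 3 by 2-phenoxyethyl in place of cyclohexyl on a carbonyl carbon. Among the measured compounds shown here, the steps that bear on it are those at the same carbonyl carbon: a 5.3-fold lower number from compound 1 to compound 3 (0.72 log units; beyond the scatter) and a 1.9-fold lower number from compound 2 to compound 3 (0.29 log units; within the scatter), both modest or within the scatter. A step of similar size, in either direction, is therefore expected for a 1.1-fold higher number from compound 3 to compound 4 (0.02 log units; within the scatter). For compound 4 the expected value is 40000 nM, with a range from 15000 nM to 110000 nM.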

Compound 4, half-maximal cytotoxic concentration: 46000 nM
Compound 4: middle estimate off by 1.2-fold (0.06 log units), on the low side; the measured number falls inside the stated range.
By their numbers in this assay, from the lowest: compounds 3, 4 and 2 (each within the scatter of the next); then compound 1.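

In this assay, 2-phenoxyethyl and cyclohexyl on the carbonyl carbon are not told apart (a 1.2-fold higher number from compound 3 to compound 4 (0.08 log units; within the scatter)), so an aromatic ring carried on a chain reads the same here as a directly attached non-aromatic ring. Compound 4 also stays within the scatter of compound 2 (a 1.6-fold lower number from compound 2 to compound 4 (0.21 log units; within the scatter)) but not of compound 1 (a 4.3-fold lower number from compound 1 to compound 4 (0.64 log units; beyond the scatter)), which leaves compound 1 apart from the other three. Nothing measured here accounts for these numbers.

Still open, on these data alone, is how a basic amine or a carboxylic acid at this position would read, and whether a chain longer than butyl would stay with compound 1 or join the others.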